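Sulfonyl-linked bipiperidines: aryl swap toward a methyl-substituted ring

The source may hold more compounds than are shown below. What is called first, only, known or untested is meant among the compounds shown, and "the series" means these compounds.

Measured so far:
- compound 1, `COc1ccccc1-c1cccc(S(=O)(=O)N2CCC(N3CCC(C)CC3)CC2)c1`: 21 nM
- compound 2, `Cc1cc(C)c(S(=O)(=O)N2CCC(N3CCC(CCO)CC3)CC2)c(C)c1`: 19 nM

Two compounds on the shared core carry a number in a functional assay on DLD-1 cells (Homo sapiens) for antiproliferative activity, read by CellTiter-Glo, with a stated time of 72 h; on this read-out lower numbers stand for stronger inhibition and higher numbers for weaker inhibition. Compound 1 gives 21 nM; compound 2 gives 19 nM. Compound 1 has the higher of the two numbers, but the gap to compound 2 lies within the scatter of this assay, so the two are read as one level and no order is drawn between them. Both carry a different aryl group on the sulfonyl side and a different substituent on the outer ring, and neither difference is resolved by these two numbers.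

Compound 3, `Cc1ccc(-c2cccc(S(=O)(=O)N3CCC(N4CCC(C)CC4)CC3)c2)cc1`, has not been measured. It differs from compound 1 in one place:
4-methylphenyl in place of 2-methoxyphenyl on an aromatic carbon
Within the data shown here, no measured pair in the set isolates this kind of exchange, so there is no step to lean on. With two aryl variants already sitting at the same level, the expected step of a 1.2-fold higher number from compound 1 to compound 3 (0.08 log units; within the scatter) is none beyond the scatter, with a widened range to cover the untested exchange. Compound 3 is therefore estimated at 25 nM in this assay, between 8 nM and 80 nM.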

Compound 3, half-maximal inhibitory concentration: 11 nM
The estimate for compound 3 lay 2.3-fold (0.36 log units) above the measured number; measured number inside the range.
By their numbers in this assay, from the lowest: compounds 3, 2 and 1 (each within the scatter of the next).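

Among these compounds, this is the first pair that isolates a single exchange on the aryl group: in this assay, 4-methylphenyl in place of 2-methoxyphenyl on an aromatic carbon gives a 1.9-fold lower number from compound 1 to compound 3 (0.28 log units; within the scatter), so compound 1 and compound 3 are read as one level. The leaving group carries an oxygen and a hydrogen-bond acceptor and the entering group carries neither, so for this pair, holding this level at this position does not depend on the 2-methoxyphenyl group or its acceptor, and the place accepts a different substitution pattern on the ring with no resolved shift. Nothing at hand accounts for the size of this step or says what lies behind it.

Going by these compounds, both groups at this position are uncharged phenyl rings bearing a small substituent, so it remains open whether a 4-aminophenyl or 4-carboxyphenyl group, or a pyridyl ring, would hold the same level in this assay. Also open, on these data alone, is whether the 2-hydroxyethyl group of compound 2 would change the number on the aryl group of compound 3, a comparison that needs a compound differing in that one place.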